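The source may report more compounds than this note shows. Statements on the series, on what has been measured and on what is new or still open speak of the compounds shown alone.

Measured compounds:
- compound 1, `COc1ccc(-c2cc3cc(-c4ccc(F)cc4)cc(C(C)=O)c3[nH]2)cc1`: > 100000 nM
- compound 2, `CC(=O)c1cc(/C=C/c2ccc(F)cc2)cc2cc(-c3ccccc3)[nH]c12`: 18500 nM

Among the measured compounds shown here, in a functional assay on MCF7 cells (Homo sapiens) for cytotoxicity, read by MTT assay, with a stated time of 2 days (a higher number here means that more compound is tolerated, a lower number that less compound is tolerated), compound 2 gives 18500 nM, the only outright number among the two results. Compound 1 reaches no number in this assay; its result is a limit, > 100000 nM, as the limit of > 100000 nM in this assay, at which 1 of the 2 values shown sits, records. For the measured compounds named here, compound 1 and compound 2 differ in more than one place, so their two values show only that one compound was toxic within the tested range and the other was not.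

Compound 3, `COc1ccc(-c2cc3cc(/C=C/c4ccc(F)cc4)cc(C(C)=O)c3[nH]2)cc1`, is not yet measured. It differs from compound 2 by methoxy in place of hydrogen on an aromatic carbon, which is methoxy in place of hydrogen on an aromatic carbon. Going by the values given here, no step of this kind has been measured here, so no measured precedent fixes its size or direction. The expectation is a step from compound 2 to compound 3 of a 1.4-fold higher number from compound 2 to compound 3 (0.13 log units; within the scatter), modest and not clearly beyond the scatter. Compound 3 is therefore estimated at 25000 nM in this assay, in the range 8000 nM to 100000 nM.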

Compound 3, concentration lethal to 50% of the cells: 83000 nM
Estimate against measurement, compound 3: 3.3-fold (0.52 log units) below; the measured number falls inside the stated range.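

Among the compounds shown here, replacing hydrogen with methoxy, which turns the phenyl of compound 2 into the 4-methoxyphenyl of compound 3, gives the first one-place comparison at this position in this assay (a 4.5-fold higher number from compound 2 to compound 3 (0.65 log units; beyond the scatter)), so more of the compound is tolerated once methoxy is present. The other step, with 2-(4-fluorophenyl)ethenyl in place of 4-fluorophenyl (an at least 1.2-fold lower number from compound 1 to compound 3 (0.08 log units; that floor lies within the scatter)), rests on the limit for compound 1, so it gives no true size or firm direction for that change. Nothing shown explains why methoxy moves the number this way.

Still open, on these data alone, is whether the step is particular to methoxy: an ethoxy group, an amine or a carboxylic acid in the same place would test that. As far as these compounds go, whether methoxy acts similarly on other cores also remains unknown.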